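From Methyl to Hydroxy on the Shared Core

The source may report more compounds than this note shows. Statements on the series, on what has been measured and on what is new or still open speak of the compounds shown alone.

Compound 1 `Cc1nc2ncc(-c3cnn(C)c3)nc2n1Cc1ccc2ncccc2c1`: > 10000 nM
Compound 2 `CC(c1cc(F)c2ncccc2c1)n1cnc2ncc(-c3cnn(C)c3)nc21`: > 10000 nM
Compound 3 `CCC(c1ccc2ncccc2c1F)n1cnc2ncc(-c3cnn(C)c3)nc21`: "not determined" (no result reported)

These three compounds were examined in a functional assay on NCI-H1993 cells (Homo sapiens) for inhibition, read by CCK-8 assay, with a stated time of 72 h; on this read-out lower numbers stand for stronger inhibition and higher numbers for weaker inhibition. Compound 1 gives > 10000 nM, which is a limit of the assay and not a number. Compound 2 gives > 10000 nM, which is likewise a limit. Compound 3 has no usable result, its entry reading "not determined" (no result reported). Compound 1 therefore stands at the limit of > 10000 nM in this assay, at which 2 of the 3 values shown sit.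

Compound 4 `Cn1cc(-c2cnc3nc(O)n(Cc4ccc5ncccc5c4)c3n2)cn1` has not yet been measured. It keeps the core of compound 1 but has hydroxy in place of methyl on an aromatic carbon, between two ring nitrogen atoms: hydroxy in place of methyl on an aromatic carbon.

Going by the values given here, no measured pair isolates this change, so the data offer no step to go by. In this assay, no step beyond the scatter is expected, and no direction can be favoured. The expected step is a number no higher from compound 1 to compound 4 (the limit leaves the size open). Compound 4 is most likely to stay at the limit, and its estimated value is 10000 nM. The expected range for compound 4 runs from 2000 nM to 20000 nM.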

Compound 4, half-maximal inhibitory concentration: > 10000 nM
Compound 4 was reported as a limit; the forecaster's own chance of this, stated with the estimate: 70%; the middle value lies on the limit itself.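

In this assay, going by these compounds alone, compound 4 gives > 10000 nM, a limit of the assay and not a number, and compound 1 also rests on a limit, so no step between the two can be read. The compounds shown leave open whether hydroxy in place of methyl changes inhibition at all.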